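The source may hold more compounds than are shown below. What is called first, only, known or untested is meant among the compounds shown, and "the series" means these compounds.

Measured so far:
Compound 1 `Oc1ccc2cc(-c3ccc(F)cc3)ccc2c1-c1cccnc1` gives 0% in an assay for inhibition of steroid 17-alpha-hydroxylase/17,20 lyase (Homo sapiens), tested at 0.2 uM; a higher number here means a stronger effect of the compound at the concentration tested, a lower number a weaker effect.
Compound 2 `COc1ccc2cc(-c3ccc(F)cc3)ccc2c1Cn1ccnc1` gives 13% in this assay.
Compound 3 `COc1ccc2cc(-c3cccc(-c4cccnc4)c3)ccc2c1` gives 3% in this assay.

All three numbers lie within the scatter of one another. Going by the values given here, compound 3 sits closest to compound 1, and its gap to compound 2 is also within the scatter, so no compound can be set apart from the others on these readings. Among the compounds with values here, no step between measured compounds differing in a single place is available, so nothing is known yet of what any one change does in this assay. Compound 4 `COc1ccc2cc(-c3cccc(-c4ccncc4)c3)ccc2c1` differs from compound 3 in one place: pyridin-4-yl in place of pyridin-3-yl on an aromatic carbon. With every measured number this low and the change confined to the pyridinyl group, no step beyond the scatter is expected from compound 3 to compound 4; the expected step is a number 2 percentage points higher from compound 3 to compound 4 (within the scatter). Compound 4 is therefore estimated at 5%, with a range from -5% to 15%.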

Compound 4, a percentage reported as inhibition, at one concentration (the size of the read-out at that concentration, not a potency): 4%
Estimate against measurement, compound 4: 1 percentage points above, and the stated range covers the measured number.
By their numbers in this assay, from the lowest: compounds 1, 3, 4 and 2 (each within the scatter of the next, the first and the last beyond it).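

Going by these compounds alone, this is the first single-place step: in this assay, pyridin-4-yl in place of pyridin-3-yl, meta to a large group, gives a number 1 percentage points higher from compound 3 to compound 4 (within the scatter). At this position, then, the two pyridinyl groups are not told apart at the concentration tested. No available data bear on the reason for this result.

Going by these compounds, whether pyridin-2-yl, a carboxylic acid or an amine such as piperidine at this place would shift the reading remains open. Also open, on these data alone, is whether any group here can raise the number beyond the scatter.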